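The source may report more compounds than this note shows. Statements on the series, on what has been measured and on what is new or still open speak of the compounds shown alone.

Working notes on the series.

Two members of the shared core have been measured in a functional assay on NCI-H520 cells (Homo sapiens) for inhibition, read by MTT assay, with a stated time of 48 h, tested at 10 uM; a higher number here means more inhibition at the concentration tested (going by the name of the read-out), a lower number less inhibition. Compound 1 `Cc1ccc(Nc2cc(NC(=O)Nc3c(Cl)cccc3Cl)ncn2)cc1F` gives 33.5%. Compound 2 `COc1ccc(F)cc1Nc1cc(NC(=O)Nc2c(Cl)cccc2Cl)ncn1` gives 38.1%. The step of a number 4.6 percentage points higher from compound 1 to compound 2 (within the scatter) exchanges one aryl group for another on the nitrogen on an aromatic ring and lies within the scatter, so the two numbers of compound 1 and compound 2 cannot be told apart on these data; compound 2 stands level with compound 1 rather than apart from it.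

Compound 3 `Cc1ccc(Nc2cc(NC(=O)Nc3c(Cl)cccc3Cl)ncn2)cc1C` is not yet measured. It differs from compound 2 by 3,4-dimethylphenyl in place of 5-fluoro-2-methoxyphenyl on a nitrogen on an aromatic ring.

Among the measured compounds shown here, the one measured step that bears on this change is the aryl exchange on the same nitrogen from compound 1 to compound 2, which gave a number 4.6 percentage points higher from compound 1 to compound 2 (within the scatter). On that basis the step from compound 2 to compound 3 in this assay is expected to stay within the scatter, with no clear direction: the expected step is a number 3.1 percentage points lower from compound 2 to compound 3 (within the scatter).

For compound 3 the estimate in this assay is 35%, with a range from 20% to 50%.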

Compound 3, a percentage reported as inhibition, at one concentration (the size of the read-out at that concentration, not a potency): 47.5%
Estimate against measurement, compound 3: 12.5 percentage points below, and the stated range covers the measured number.
By their numbers in this assay, from the lowest: compounds 1, 2 and 3 (each within the scatter of the next, the first and the last beyond it).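

In this assay, among the compounds shown here, methyl in place of fluoro on an aromatic carbon gives a number 14 percentage points higher from compound 1 to compound 3 (beyond the scatter), the first step to lie beyond the scatter, although it remains modest. For the compounds shown here, the larger exchange of 3,4-dimethylphenyl in place of 5-fluoro-2-methoxyphenyl on the same nitrogen gives a number 9.4 percentage points higher from compound 2 to compound 3 (within the scatter), so replacing the whole aryl group, with the loss of its oxygen and fluorine, yields no step that can be separated from the scatter. The series therefore shows a readable change for a single exchange on this aryl group, but no measurement of any property of these compounds explains it.

Going by these compounds, it remains open whether an ethyl, a trifluoromethyl or an amine on that aromatic carbon would extend, hold or reverse the step seen with methyl, and whether the step would persist with a different substitution elsewhere on the aryl group. Because every number comes from a single concentration, the compounds shown also leave open how their potencies compare.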